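The source may hold more compounds than are shown below. What is called first, only, known or untested is meant among the compounds shown, and "the series" means these compounds.

In an ADME assay on microsomes from liver (Homo sapiens) for metabolic stability, read by LC-MS, using NADPH, with stated times of 10 min and 60 min (a higher number here means faster removal of the compound, a lower number slower removal), compound 1 `Clc1cccc(CNCC[C@@]2(c3ccccn3)CCOC3(CCOC3)C2)c1` gives 22.1 mL/min/kg and compound 2 `Fc1ccc([C@]2(CCNCc3cccc(Cl)c3)CCO[C@]3(CCOC3)C2)nc1` gives 29.2 mL/min/kg as its clearance. Compound 3 `Fc1ccc([C@]2(CCNCc3scc4c3CCC4)CCOC3(CCOC3)C2)cc1` stands highest of the three at 157 mL/min/kg with gaps to both others that lie beyond the scatter. Compound 4 `Fc1ccc([C@]2(CCNCc3scc4c3COC4)CCOC3(CCOC3)C2)cc1` differs from compound 3 in one place: a group of 8 heavy atoms (6 carbon, 1 oxygen, 1 sulfur; one five-membered non-aromatic ring with 1 hetero atom, one five-membered aromatic ring with 1 hetero atom) in place of a group of 8 heavy atoms (7 carbon, 1 sulfur; one five-membered non-aromatic ring of carbon only, one five-membered aromatic ring with 1 hetero atom), on a saturated chain carbon bound to an amine nitrogen while the rest of the molecule stays the same. Among the measured compounds shown here, no two measured compounds differ in one place alone, so the data offer no direct guide to this exchange. Since compound 3 sits at 157 mL/min/kg at the top of these numbers, a fall seems likelier than a rise. The expected change is a fall, estimated at a 2.4-fold lower number from compound 3 to compound 4 (0.38 log units; beyond the scatter) and so modestly beyond the scatter. For compound 4 the estimated clearance is 65 mL/min/kg with 30 mL/min/kg to 130 mL/min/kg as its likely range.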

Compound 4, clearance: 191 mL/min/kg
The estimate for compound 4 lay 2.9-fold (0.47 log units) below the measured number; measured number outside the range, above it.
By their numbers in this assay, from the lowest: compounds 1 and 2 (each within the scatter of the next); then compounds 3 and 4 (each within the scatter of the next).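

Putting a five-membered non-aromatic ring with 1 hetero atom, an oxygen, in place of the carbon-only ring gives a 1.2-fold higher number from compound 3 to compound 4 (0.09 log units; within the scatter) in this assay on this fused group. At this place, on a saturated chain carbon bound to an amine nitrogen, the exchange therefore does not separate the two compounds. Nothing available explains this result. Still open, from the compounds shown here alone, is whether an amine nitrogen or a sulfone in that non-aromatic ring, or a plain phenyl in place of the whole fused group, would move the number beyond the scatter in this assay.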